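Replacing the sulfonyl side chain with a methylphenyl group

A few compounds are considered here, and "the series" means these few. Any claim that something is new, unique, unknown or untested is made for them only; others in the source may bear on it.

Compound 2 `CC(C)OC(=O)NCCS(=O)(=O)NC(=O)c1ccc(Nc2nc(NC3(c4ccc(Cl)cc4)CC3)nc(OCC(F)(F)F)n2)cc1` stands highest of the two numbers in a physicochemical assay for permeability, using PAMPA, at pH 7.4 (on this read-out higher numbers stand for higher permeability and lower numbers for lower permeability), at 71 nm/s. Within the data shown here, compound 1 `CC(C)(C)NC(=O)NCCS(=O)(=O)NC(=O)c1ccc(Nc2nc(NC3(c4ccc(Cl)cc4)CC3)nc(OCC(F)(F)F)n2)cc1` gives 49 nm/s in this assay, and the only measured step, a 1.4-fold higher number from compound 1 to compound 2 (0.16 log units; within the scatter), sits within the scatter. Compound 3 `Cc1ccccc1S(=O)(=O)NC(=O)c1ccc(Nc2nc(NC3(c4ccc(Cl)cc4)CC3)nc(OCC(F)(F)F)n2)cc1` differs from compound 2 by 2-methylphenyl in place of 2-((isopropoxycarbonyl)amino)ethyl on a sulfonyl sulfur. That earlier step touched the same side chain but was small, so it gives little guidance; the present change is larger. Compound 3 is expected to show a 2.0-fold higher number from compound 2 to compound 3 (0.29 log units; within the scatter) in this assay. The estimate for compound 3 is 140 nm/s, within a range from 50 nm/s to 400 nm/s.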

Compound 3, apparent permeability: 265 nm/s
For compound 3 the middle estimate is 1.9-fold (0.28 log units) below the measured one; the range from low to high includes it.
By their numbers in this assay, from the lowest: compounds 1 and 2 (each within the scatter of the next); then compound 3.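

Among these compounds, on the sulfonyl sulfur, 2-methylphenyl in place of 2-((isopropoxycarbonyl)amino)ethyl gives a 3.7-fold higher number from compound 2 to compound 3 (0.57 log units; beyond the scatter) in this assay, the first step beyond the scatter. With 2-(((tert-butyl)carbamoyl)amino)ethyl as the group replaced, the same change gives a 5.4-fold higher number from compound 1 to compound 3 (0.73 log units; beyond the scatter), so exchanging the whole chain moves this read-out where the exchange on its carbonyl carbon did not. Nothing shown here accounts for the rise. The compounds leave open whether the aromatic ring, its methyl or the loss of the chain carries the step. They also leave open how an unsubstituted phenyl, a plain methyl or a chain ending in an amine would read on the sulfonyl sulfur in this assay.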